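Shifting the methyl on the outer ring of compound 1

A few compounds are considered here, and "the series" means these few. Any claim that something is new, unique, unknown or untested is made for them only; others in the source may bear on it.

Measured so far:
compound 1 `COc1cc(-c2ccnc3cc(-c4ccc(Cl)cc4)nn23)cc(OC)c1OC`: 1490 nM
compound 2 `COc1cc(-c2ccnc3cc(-c4ccc(C)cc4)nn23)cc(OC)c1OC`: 21 nM
compound 3 `COc1cc(-c2ccnc3cc(-c4ccc(C(F)(F)F)cc4)nn23)cc(OC)c1OC`: 1840 nM

In a functional assay on HeLa cells (Homo sapiens) for inhibition, read by CCK-8 assay, with a stated time of 48 h (a higher number here means a weaker inhibitor, a lower number a stronger inhibitor), compound 1 gives 1490 nM, the second highest of the three numbers. Compound 3 sits close by, with a 1.2-fold higher number from compound 1 to compound 3 (0.09 log units; within the scatter), while compound 2 stands far apart, with a 71-fold lower number from compound 1 to compound 2 (1.85 log units; beyond the scatter).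

Compound 4 `COc1cc(-c2ccnc3cc(-c4cccc(C)c4)nn23)cc(OC)c1OC` has not yet been measured. It differs from compound 1 in one place: 3-methylphenyl in place of 4-chlorophenyl on an aromatic carbon.

Within the data shown here, two measured steps bear on this change. The step of a 71-fold lower number from compound 1 to compound 2 (1.85 log units; beyond the scatter) shows that a methyl in place of chloro can lower the number a great deal, and the step of an 88-fold higher number from compound 2 to compound 3 (1.94 log units; beyond the scatter) shows the same gap from the other side. Neither step, however, involves a 3-methylphenyl group; compound 2 carries its methyl elsewhere on the ring, so whether the large gain carries over is uncertain. A lower number than for compound 1 is therefore expected, though by a smaller step than a 71-fold lower number from compound 1 to compound 2 (1.85 log units; beyond the scatter). The step expected from this change is a 6.0-fold lower number from compound 1 to compound 4 (0.78 log units; beyond the scatter). Compound 4 is thus estimated at 250 nM, within a range from 30 nM to 2000 nM.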

Compound 4, half-maximal inhibitory concentration: 4230 nM
The estimate for compound 4 lay 17-fold (1.23 log units) below the measured number; the measured number lies above the stated range.
By their numbers in this assay, from the lowest: compound 2; then compounds 1 and 3 (each within the scatter of the next); then compound 4.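

Moving the methyl from 4-methylphenyl to 3-methylphenyl in this assay gives a 200-fold higher number from compound 2 to compound 4 (2.30 log units; beyond the scatter), so the low number of compound 2 depends on where the methyl sits, and not merely on the ring carrying one. Compound 4 also falls behind the two compounds with other groups, with a 2.8-fold higher number from compound 1 to compound 4 (0.45 log units; beyond the scatter) and a 2.3-fold higher number from compound 3 to compound 4 (0.36 log units; beyond the scatter), which makes it the weakest of the four and shows that a methyl on this ring can do worse than a chloro or a trifluoromethyl. No measurement here explains why the shift has so large an effect.

On these data alone, it remains open whether a larger group such as ethyl, or an oxygen-linked one such as methoxy, could replace the methyl of compound 2 and keep its low number. An unsubstituted phenyl would also show how much of the gap comes from the methyl itself.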